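A few compounds are considered here, and "the series" means these few. Any claim that something is new, unique, unknown or untested is made for them only; others in the source may bear on it.

Compound 1 `CC(C)[C@H](NC(=O)COc1cccc2ccccc12)C(=O)N[C@@H](CC(=O)O)C(=O)CSc1nc(-c2ccccc2)no1` gives 102000 nM in a functional assay on Jurkat cells (Homo sapiens) for inhibition; a higher number here means a weaker inhibitor, a lower number a stronger inhibitor.
Compound 2 `CC(C)[C@H](NC(=O)COc1cccc2ccccc12)C(=O)N[C@@H](CC(=O)O)C(=O)COc1ccccn1` reaches only the limit > 200000 nM of this assay.

Compound 2 thus stands at the limit of this assay, the weaker side of the two values shown, and the step of an at least 1.9-fold higher number from compound 1 to compound 2 (0.29 log units; that floor lies within the scatter) can be read only as a floor, as the limit line shows (the limit of > 200000 nM in this assay, at which 1 of the 2 values shown sits). Compound 3 `CC(C)[C@H](NC(=O)COc1cccc2ccccc12)C(=O)N[C@@H](CC(=O)O)C(=O)COc1nccc(C(F)(F)F)n1` differs from compound 2 by 4-(trifluoromethyl)pyrimidin-2-yl in place of pyridin-2-yl on an oxygen on a saturated carbon. Going by the values given here, no measured step involves this change; the single measured step alters a different group on the same chain carbon, so it gives no direct guide. Compound 3 is therefore expected to stay near the limit, estimated at 200000 nM within 60000 nM to 600000 nM. The expected step of a number no higher from compound 2 to compound 3 (the limit leaves the size open) is thus one within the scatter.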

Compound 3, half-maximal inhibitory concentration: > 200000 nM
Compound 3 ended at the assay's limit; the forecaster's own chance of this, stated with the estimate: 60%; the middle value sits exactly at the limit.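

In this assay compound 2 and compound 3 both sit at a limit, and the step between them cannot be read. The change from the (3-phenyl-1,2,4-oxadiazol-5-yl)sulfanyl group to the (4-(trifluoromethyl)pyrimidin-2-yl)oxy group gives only a floor, an at least 1.9-fold higher number from compound 1 to compound 3 (0.29 log units; that floor lies within the scatter). Two different rings on this oxygen now end at the same limit: the limit of > 200000 nM in this assay, at which 2 of the 3 values shown sit.

On these data alone, how far beyond the limit either compound lies stays open. Also open, as far as these compounds go, is whether an amine on this chain carbon, in place of the oxygen-linked rings, would give a value inside the range of this assay.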